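The source may report more compounds than this note shows. Statements on the series, on what has been measured and on what is new or still open speak of the compounds shown alone.

Measured compounds:
Compound 1, `COc1cc(N/C=C\C(=O)c2cn(-c3ccccc3)nc2-c2ccccc2)cc(OC)c1OC`: 36200 nM
Compound 2, `O=C(/C=C\Nc1ccc(Cl)cc1)c1cn(-c2ccccc2)nc1-c1ccc(F)cc1`: 21300 nM
Compound 3, `COc1cc(N/C=C\C(=O)c2cn(-c3ccccc3)nc2-c2ccc(F)cc2)cc(OC)c1OC`: 32800 nM

All three were tested in an ADME assay on HaCaT cells (Homo sapiens) for antiproliferative activity, read by MTT assay, with a stated time of 48 h; on this read-out higher numbers stand for weaker inhibition and lower numbers for stronger inhibition. Compound 3 gives a number that sits between those of compound 1 and compound 2, and the gaps to both lie within the usual scatter of repeated measurements, so no ranking among the three can be drawn from these figures.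

Compound 4, `COc1cc(N/C=C\C(=O)c2cn(-c3ccccc3)nc2-c2ccc(Cl)cc2)cc(OC)c1OC`, is the next compound in this series. It differs from compound 3 in one place: chloro in place of fluoro on an aromatic carbon. Going by the values given here, only one measured step touches the same ring, namely a 1.1-fold lower number from compound 1 to compound 3 (0.04 log units; within the scatter), where a fluoro replaced a hydrogen at that position and the number hardly moved. Among the compounds with values here, no measured pair shows a fluoro giving way to a chloro, so the change from compound 3 to compound 4 rests on thin evidence. Given that the earlier substitution at this position left the number within the scatter, the expectation for compound 4 is a step of a 1.2-fold lower number from compound 3 to compound 4 (0.07 log units; within the scatter), that is, no shift beyond the scatter in either direction. The estimate for compound 4 in this assay is therefore 28000 nM, with a range from 12000 nM to 65000 nM.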

Compound 4, half-maximal inhibitory concentration: 46600 nM
For compound 4 the middle estimate is 1.7-fold (0.22 log units) below the measured one; the measured number falls inside the stated range.
By their numbers in this assay, from the lowest: compounds 2, 3, 1 and 4 (each within the scatter of the next, the first and the last beyond it).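

In this assay, this position on the shared core now carries three different occupants: hydrogen in compound 1, fluoro in compound 3 and chloro in compound 4. Changing the 4-fluorophenyl to a 4-chlorophenyl gives a 1.4-fold higher number from compound 3 to compound 4 (0.15 log units; within the scatter) and putting chloro in place of hydrogen gives a 1.3-fold higher number from compound 1 to compound 4 (0.11 log units; within the scatter) while the earlier fluoro change gave a 1.1-fold lower number from compound 1 to compound 3 (0.04 log units; within the scatter) so none of the three steps among these compounds separates its pair, and swapping one halogen for another at this position has not moved the number beyond what repeated measurements would show. Nothing measured alongside these numbers accounts for them, and their small size gives no ground for ranking hydrogen, fluoro and chloro here.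

Fluoro and chloro are both single-atom groups, so it remains open whether something of a different kind at this position, such as an amine, a carboxylic acid or a longer alkyl chain, would shift the number beyond the scatter. As far as these compounds go, it is also open whether a change from fluoro to chloro here would read the same on the core of compound 2.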